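Propargylamine thioethers and the step to a methoxy analogue

The source may hold more compounds than are shown below. What is called first, only, known or untested is meant among the compounds shown, and "the series" means these compounds.

Compound 1 `C#CCNC1CCc2c(SCc3ccc(Cl)cc3Cl)cccc21` — 22300 nM
Compound 2 `C#CCNC1CCc2c(SCc3cccc(Br)c3)cccc21` — > 100000 nM
Compound 3 `C#CCNC1CCc2c(SCCc3ccc(C(F)(F)F)cc3)cccc21` — 8780 nM

Three compounds sharing one core were tested in an ADME assay on isolated protein for inhibition of Amine oxidase [flavin-containing] B (Homo sapiens); a higher number here means a weaker inhibitor, a lower number a stronger inhibitor. Compound 2 gives only a limit in this assay, > 100000 nM (the limit of > 100000 nM in this assay, at which 1 of the 3 values shown sits), so it yields no number. Of the two numbers, compound 3 holds the lower with 8780 nM; compound 1, with 22300 nM, stands above it by a gap beyond the usual scatter of this assay. Compound 3 is thus the strongest inhibitor among the numbers shown.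

The next compound, compound 4 `C#CCNC1CCc2c(SCCc3ccc(OC)cc3)cccc21`, has not been measured. It differs from compound 3 in one place: methoxy in place of trifluoromethyl on an aromatic carbon. The change sits on an aromatic carbon of a six-membered aromatic ring of carbon only, para to a large group, and the rest of the structure is kept.

Among the measured compounds shown here, no measured step involves a change of this kind, so the expectation rests on compound 3 alone. Compound 4 is expected to be a somewhat weaker inhibitor than compound 3 in this assay, with an estimated step of a 1.7-fold higher number from compound 3 to compound 4 (0.23 log units; within the scatter). For compound 4 the estimated half-maximal inhibitory concentration is 15000 nM, with a range from 4000 nM to 60000 nM.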

Compound 4, half-maximal inhibitory concentration: 4590 nM
The estimate for compound 4 lay 3.3-fold (0.51 log units) above the measured number; the range from low to high includes it.
By their numbers in this assay, from the lowest: compounds 4 and 3 (each within the scatter of the next); then compound 1. At a limit, above all of these: compound 2.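

In this assay the exchange gives a 1.9-fold lower number from compound 3 to compound 4 (0.28 log units; within the scatter), so methoxy in place of trifluoromethyl on an aromatic carbon, para to a large group, stays within the usual scatter of repeated measurements. Among the compounds shown here, this is the first step that can be read at a single place, and it shows that the reading at this position holds when trifluoromethyl, with 4 heavy atoms and 0 hydrogen-bond acceptors, gives way to methoxy, with 2 heavy atoms and 1 hydrogen-bond acceptor. Nothing measured among these compounds bears on why the two groups give readings within the scatter of each other.

As far as these compounds go, the two groups at this position therefore say little about how far it tolerates change, and whether an amine, a carboxylic acid or a nitrile in the same place would leave the reading within the scatter remains open. Also open, from the compounds shown here alone, is whether methoxy would give a similar result on the core of compound 1 or compound 2, which differ from compound 4 in more than one place.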